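This account rests on a few compounds, and the source may have more. Where it says the series, first, only, none or still open, it means among the compounds named here.

Measured in an ADME assay on L6 cells (Rattus norvegicus) for cytotoxicity, read by resazurin assay, with a stated time of 72 h; a higher number here means a weaker inhibitor, a lower number a stronger inhibitor:
Compound 1 `CN1CCN(CC(=O)N2CCC3(N(C)C)CC(c4ccccc4)C2C(c2ccccc2)C3)CC1`: 195000 nM
Compound 2 `CN1CCN(CC(=O)N2CCC3(N4CCCCC4)CC(c4ccccc4)C2C(c2ccccc2)C3)CC1`: 177000 nM
Compound 3 `CN1CCN(CCC(=O)N2CCC3(N4CCCCC4)CC(c4ccccc4)C2C(c2ccccc2)C3)CC1`: 120000 nM

Compound 2 lies within the scatter of both its measured neighbours: there is a 1.1-fold lower number from compound 1 to compound 2 (0.04 log units; within the scatter), and there is a 1.5-fold lower number from compound 2 to compound 3 (0.17 log units; within the scatter). Compound 4 `CN1CCN(CC(=O)N2CCC3(N4CCCC4)CC(c4ccccc4)C2C(c2ccccc2)C3)CC1` has pyrrolidin-1-yl in place of piperidin-1-yl on a saturated ring carbon. The first of those steps swapped the group on this same ring carbon, so it bears most directly, while the second concerned a saturated chain carbon bound to a carbonyl carbon. Neither went beyond the scatter, so no step beyond it is expected in this assay. The expected step is a 1.0-fold lower number from compound 2 to compound 4 (0.02 log units; within the scatter). For compound 4 the estimate is 170000 nM, with an expected range from 105000 nM to 270000 nM.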

Compound 4, half-maximal inhibitory concentration: 69100 nM
Compound 4: middle estimate off by 2.5-fold (0.39 log units), on the high side, outside the stated range (below it).
By their numbers in this assay, from the lowest: compounds 4, 3, 2 and 1 (each within the scatter of the next, the first and the last beyond it).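

In this assay the change to pyrrolidin-1-yl gives a 2.6-fold lower number from compound 2 to compound 4 (0.41 log units; beyond the scatter) and, starting from dimethylamino, a 2.8-fold lower number from compound 1 to compound 4 (0.45 log units; beyond the scatter) so the group on this saturated ring carbon can shift the number modestly beyond the scatter, which the change from dimethylamino to piperidin-1-yl did not do. No measurement at hand explains what sets the five-membered ring apart. Still open, from the compounds shown here alone, is how azetidin-1-yl or morpholin-4-yl would behave on this carbon, and whether pyrrolidin-1-yl would give a similar step alongside the longer chain of compound 3.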